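The source may hold more compounds than are shown below. What is called first, only, known or untested is meant among the compounds shown, and "the series" means these compounds.

In a functional assay on FM3A cells (Mus musculus) for antiproliferative activity, with a stated time of 48 h (on this read-out lower numbers stand for stronger inhibition and higher numbers for weaker inhibition), compound 1 (`C=C(Br)C(=O)Nc1ccc(/C=C/C(=O)c2ccc(OCC)cc2)cc1`) gives 680 nM and compound 2 (`C=C(Br)C(=O)Nc1ccc(C(=O)/C=C/c2ccccc2)cc1`) gives 690 nM so compound 2 stands within the scatter of compound 1. Compound 3 (`C=C(Br)C(=O)Nc1ccc(C(=O)/C=C/c2ccc(OC)cc2)cc1`) differs from compound 2 by a single change (methoxy in place of hydrogen on an aromatic carbon) with methoxy in place of hydrogen on an aromatic carbon, para to a large group. No measured step among these compounds shows what this change does. In this assay the expected 1.8-fold lower number from compound 2 to compound 3 (0.26 log units; within the scatter) is modest and points toward stronger inhibition. Compound 3 is estimated at 380 nM with an expected range of 130 nM to 1000 nM on this reasoning.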

Compound 3, half-maximal inhibitory concentration: 1000 nM
Compound 3: the middle estimate sits 2.6-fold (0.42 log units) below what was measured; the measured number falls inside the stated range.
By their numbers in this assay, from the lowest: compounds 1, 2 and 3 (each within the scatter of the next).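

In this assay, within the data shown here, the change from phenyl to 4-methoxyphenyl gives a 1.4-fold higher number from compound 2 to compound 3 (0.16 log units; within the scatter) and provides the first reading for methoxy in place of hydrogen at this place, para to a large group. On this one pair, methoxy is accepted there without a step that can be told apart from repeated measurement. Nothing available bears on the reason.

As far as these compounds go, whether an amine, a carboxylic acid or a longer chain such as butoxy at this place would give a step beyond the scatter stays open. This single pair also cannot show whether methoxy would read the same on another core.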